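A Hydroxyphenyl Analogue Expected Near the Weaker End

The source may report more compounds than this note shows. Statements on the series, on what has been measured and on what is new or still open speak of the compounds shown alone.

Of the compounds shown here, three have been measured in a functional assay on K562 cells (Homo sapiens) for antiproliferative activity, read by resazurin assay, with a stated time of 72 h; a higher number here means a weaker inhibitor, a lower number a stronger inhibitor. Compound 1 `COc1ccc(-c2nc3c(c(-c4ccccc4)nn3-c3ccccc3)c(-c3ccc(O)cc3)c2C#N)cc1` gives 2100 nM. Compound 3 `COc1cc(-c2c(C#N)c(-c3cccs3)nc3c2c(-c2ccccc2)nn3-c2ccccc2)ccc1O` gives 15400 nM. Compound 2 `COc1ccc(-c2c(C#N)c(-c3ccccc3)nc3c2c(-c2ccccc2)nn3-c2ccccc2)cc1OC` reaches only the limit of > 25000 nM, which is a boundary of the measurement and not a number; it stands at the limit of > 25000 nM in this assay, at which 1 of the 3 values shown sits. Among these three, compound 2 therefore sits with the weakest result on show, while compound 1 and compound 3 give numbers inside the measurable range.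

Compound 4 `N#Cc1c(-c2ccccc2)nc2c(c(-c3ccccc3)nn2-c2ccccc2)c1-c1ccc(O)cc1` is not yet measured. It differs from compound 2 by 4-hydroxyphenyl in place of 3,4-dimethoxyphenyl on an aromatic carbon, so that compound 4 carries the same 4-hydroxyphenyl that compound 1 carries at that position, while keeping the phenyl group of compound 2 elsewhere. Among the compounds with values here, no measured pair differs in this one place, so the size of the step cannot be read from data. The expectation is a move toward a stronger inhibitor, an at least 5.5-fold lower number from compound 2 to compound 4 (0.74 log units; beyond the scatter), because compound 1 with the same 4-hydroxyphenyl gives 2100 nM. For compound 4 the estimate in this assay is 4500 nM, with a range from 1500 nM to 18000 nM.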

Compound 4, half-maximal inhibitory concentration: 9600 nM
The estimate for compound 4 lay 2.1-fold (0.33 log units) below the measured number, within the range that was stated.
By their numbers in this assay, from the lowest: compound 1; then compounds 4 and 3 (each within the scatter of the next). At a limit, above all of these: compound 2.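

In this assay, swapping the 3,4-dimethoxyphenyl ortho to the cyano group for 4-hydroxyphenyl now has a measured direction, with an at least 2.6-fold lower number from compound 2 to compound 4 (0.41 log units; beyond the scatter). Compound 2 stands at a limit, so the size of that step is only a bound: the limit of > 25000 nM in this assay, at which 1 of the 4 values shown sits. The 4-hydroxyphenyl does not carry the whole of the number of compound 1 on its own, since a second change, hydrogen in place of methoxy on an aromatic carbon, gives a 4.6-fold higher number from compound 1 to compound 4 (0.66 log units; beyond the scatter).

The compounds shown do not separate the part played by the hydroxy group at this position from the part played by the loss of the two methoxy groups. As far as these compounds go, how an amine or a carboxylic acid in place of that hydroxy group would read here remains open.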